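A few compounds are considered here, and "the series" means these few. Any claim that something is new, unique, unknown or untested is made for them only; others in the source may bear on it.

Compound 1 `Cn1cc(C2CCN=C(N)N2)c2ccccc21` gives 4290 nM in a functional assay on HT-29 cells (Homo sapiens) for cytotoxicity, read by sulforhodamine B assay, with a stated time of 72 h; a higher number here means a weaker inhibitor of growth, a lower number a stronger inhibitor of growth.
Compound 2 `Cn1cc(C2CCN=C(N)N2)c2ccc(Br)cc21` gives 4560 nM in this assay.
Compound 3 `CC(=O)/N=C1\NCCC(c2cn(C)c3ccccc23)N1` gives 7400 nM in this assay.

Compounds 1 and 2 share one core, and compound 2 carries the change (bromo in place of hydrogen on an aromatic carbon). That change produced the step of a 1.1-fold higher number from compound 1 to compound 2 (0.03 log units; within the scatter), so the two values sit within the usual scatter of each other. Compound 3 has a different core; how its core differs from that of compound 1 is not broken down here, and its value lies within the scatter of both compound 1 and compound 2.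

Compound 4 `CC(=O)/N=C1\NCCC(c2cn(C)c3ccc(Br)cc23)N1` is not yet measured. Going by the values given here, it differs from compound 3 by bromo in place of hydrogen on an aromatic carbon, which is the same change as the one from compound 1 to compound 2, at the same kind of place. On the core of compound 1 this change made no step beyond the scatter, so for compound 4 a step of a 1.1-fold higher number from compound 3 to compound 4 (0.03 log units; within the scatter) in this assay is expected, resting on the step of a 1.1-fold higher number from compound 1 to compound 2 (0.03 log units; within the scatter). The estimate for compound 4 is 7900 nM, expected to fall between 3900 nM and 16000 nM.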

Compound 4, concentration for 50% growth inhibition: 310 nM
Beside the measured number, compound 4's estimate is 25-fold (1.41 log units) above it, outside the stated range (below it).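

Bromo in place of hydrogen on an aromatic carbon gave a 24-fold lower number from compound 3 to compound 4 (1.38 log units; beyond the scatter) in this assay, so on the core of compound 3 this single change makes a large difference. The same change did not act this way on the core of compound 1, which shows that its effect cannot simply be carried from one core to the other in this series: the same change on two cores in this assay, a 1.1-fold higher number (0.03 log units; within the scatter) from compound 1 to compound 2 and a 24-fold lower number (1.38 log units; beyond the scatter) from compound 3 to compound 4, 25-fold (1.40 log units) apart, beyond the scatter of two such steps. Going by these compounds alone, this does not show why the two cores respond differently, and with only one pair on each core and one place on the ring, it sets no rule for other cores.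

The compounds shown leave open whether the large step on the core of compound 3 is special to bromo or would also appear with another group at the same place, such as chloro, methoxy or an amine. They also leave open what bromo would do on a different aromatic carbon of that core.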